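The compounds below may be only part of what the source reports. "The series", "measured", "known", "first", "only" and "open" are said of these compounds alone.

In an ADME assay on MT4 cells (Homo sapiens) for cytotoxicity, read by MTT assay, with a stated time of 5 days (on this read-out higher numbers stand for lower toxicity in this test and lower numbers for higher toxicity in this test), two compounds built on a shared core have been measured so far. Compound 1 `Cc1cc(C)c(Oc2cc(Nc3ccc([N+](=O)[O-])cc3)[nH]c(=O)c2)c(C)c1` gives 26000 nM, and compound 2 `Cc1cc(C)c(Oc2cc(Nc3ccc(C#N)cc3)[nH]c(=O)c2)c(C)c1` gives 32000 nM. For the measured compounds named here, these two numbers lie within the usual scatter of each other, so compound 2 stands level with compound 1, the only other measured compound.

Compound 3 `Cc1ccc(Nc2cc(Oc3c(C)cc(C)cc3C)cc(=O)[nH]2)cc1` has not yet been measured. It differs from compound 2 by methyl in place of cyano on an aromatic carbon, para to a large group: methyl in place of cyano on an aromatic carbon.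

Going by the values given here, only one measured step bears on this change. Putting cyano in place of nitro on an aromatic carbon gave a 1.2-fold higher number from compound 1 to compound 2 (0.09 log units; within the scatter). That step does not involve methyl, so it is weak evidence, but it offers no reason to expect a real shift. The expected step is none beyond the scatter, estimated as a 1.3-fold lower number from compound 2 to compound 3 (0.11 log units; within the scatter). Compound 3 is expected to give about 25000 nM, with an estimated range of 10000 nM to 60000 nM.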

Compound 3, half-maximal cytotoxic concentration: 37000 nM
Beside the measured number, compound 3's estimate is 1.5-fold (0.17 log units) below it, within the range that was stated.
By their numbers in this assay, from the lowest: compounds 1, 2 and 3 (each within the scatter of the next).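

In this assay, methyl on this aromatic carbon, para to a large group, leaves the read-out level with cyano (a 1.2-fold higher number from compound 2 to compound 3 (0.06 log units; within the scatter)) and level with nitro (a 1.4-fold higher number from compound 1 to compound 3 (0.15 log units; within the scatter)). The earlier pair compared only cyano and nitro, whereas methyl has no hydrogen-bond acceptor and cyano has one, and this difference still produces no step beyond the usual scatter. Across these three compounds, then, the read-out does not separate the groups tried at this position, and no measurement here offers an explanation for that.

As far as these compounds go, whether the level read-out would hold for an amine, a carboxylic acid or a longer chain on the same carbon remains open. Also open, from the compounds shown here alone, is whether it would hold with a change elsewhere on the shared core, which all three compounds keep.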